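This account rests on a few compounds, and the source may have more. Where it says the series, first, only, none or still open, it means among the compounds named here.

Compound 3 `CCCCC#Cc1cn(C/C=C\CN2C(=O)c3ccccc3C2=O)c(=O)[nH]c1=O` gives the highest number of the three measured compounds in a functional assay on L1210 cells (Mus musculus) for antiproliferative activity, read by MTT assay, with a stated time of 2 days (a lower number here means a stronger inhibitor, a higher number a weaker inhibitor), namely 109000 nM. Compound 1 `CCCCCCCCC#Cc1cn(C/C=C\CN2C(=O)c3ccccc3C2=O)c(=O)[nH]c1=O` gives 45000 nM in this assay, and compound 2 `CCCCCc1ccc(C#Cc2cn(C/C=C\CN3C(=O)c4ccccc4C3=O)c(=O)[nH]c2=O)cc1` gives 28000 nM. The step of a 2.4-fold higher number from compound 1 to compound 3 (0.38 log units; beyond the scatter) and the step of a 3.9-fold higher number from compound 2 to compound 3 (0.59 log units; beyond the scatter) both place compound 3 apart from the other two, while the step of a 1.6-fold lower number from compound 1 to compound 2 (0.21 log units; within the scatter) lies within the scatter.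

Compound 4 `CCCCc1ccc(C#Cc2cn(C/C=C\CN3C(=O)c4ccccc4C3=O)c(=O)[nH]c2=O)cc1` differs from compound 3 by 4-butylphenyl in place of butyl on a triple-bonded carbon. The measured step that bears on this change most directly is a 3.9-fold higher number from compound 2 to compound 3 (0.59 log units; beyond the scatter), which runs in the opposite direction and involves a 4-pentylphenyl group rather than the 4-butylphenyl group of compound 4. The step of a 1.6-fold lower number from compound 1 to compound 2 (0.21 log units; within the scatter) shows that exchanging an alkyl chain for a pentyl-bearing phenyl ring on the triple-bonded carbon changes the number little when the alkyl chain is octyl. Taken together, a modest step downward is expected for compound 4 in this assay, roughly the size of a 3.4-fold lower number from compound 3 to compound 4 (0.53 log units; beyond the scatter), bringing it near compound 2 because of 28000 nM. Compound 4 is therefore estimated at 32000 nM, with a range from 12000 nM to 85000 nM.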

Compound 4, half-maximal inhibitory concentration: 31000 nM
Estimate against measurement, compound 4: 1.0-fold (0.01 log units) above; low and high end bracket the measured number.
By their numbers in this assay, from the lowest: compounds 2, 4 and 1 (each within the scatter of the next); then compound 3.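

In this assay, the exchange at the triple-bonded carbon now has a direct reading: 4-butylphenyl in place of butyl gives a 3.5-fold lower number from compound 3 to compound 4 (0.55 log units; beyond the scatter), so this change lowers the number when the group it replaces is butyl. The ring-bearing groups cannot be told apart by the length of their chains, since pentyl and butyl on the phenyl ring give a 1.1-fold higher number from compound 2 to compound 4 (0.04 log units; within the scatter), and the ring is not needed for a number in this range, since 4-butylphenyl in place of octyl gives a 1.5-fold lower number from compound 1 to compound 4 (0.16 log units; within the scatter). Among the four compounds shown, butyl alone stands apart at this place, while octyl, 4-pentylphenyl and 4-butylphenyl cannot be ordered, and no compound here goes against that pattern.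

From the compounds shown here alone, it remains open whether an unsubstituted phenyl, a phenyl ring carrying an amine or a carboxylic acid, or a chain ending in a hydroxyl group on the triple-bonded carbon would stay near compound 4 at 31000 nM, and whether a chain shorter than butyl would raise the number further. Nothing given here explains why butyl differs from the other three groups.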